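The source may hold more compounds than are shown below. What is called first, only, known or untested is meant among the compounds shown, and "the series" means these compounds.

Measured compounds:
- compound 1, `Fc1ccc(C2CC(c3ccccc3)=NN2c2ccc(-c3ccccc3)nn2)cc1`: 100000 nM
- compound 2, `FC(F)(F)c1ccc(C2CC(c3ccccc3)=NN2c2ccc(-c3ccccc3)nn2)cc1`: 100000 nM
- compound 3, `COc1cc(C2CC(c3ccccc3)=NN2c2ccc(-c3ccccc3)nn2)cc(OC)c1OC`: 70000 nM

All three share one core and were tested in a functional assay on MCF7 cells (Homo sapiens) for antiproliferative activity, read by MTT assay, with a stated time of 24 h; a lower number here means a stronger inhibitor, a higher number a weaker inhibitor. Within the data shown here, compound 1 gives 100000 nM and compound 2 gives 100000 nM; the one measured step between compounds that differ in a single place is no change at the digits printed from compound 1 to compound 2 (within the scatter). Compound 3 gives 70000 nM, the lowest of the three numbers, yet its gap to compound 1 and to compound 2 lies within the scatter, so the three compounds cannot be ranked against each other on these data.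

Compound 4, `COc1cc(C2CC(c3ccc(Cl)cc3)=NN2c2ccc(-c3ccccc3)nn2)cc(OC)c1OC`, is not yet measured. It differs from compound 3 by chloro in place of hydrogen on an aromatic carbon. Among the measured compounds shown here, no measured step concerns a change of this kind: the only step available swaps one group for another at a different position and was itself flat. There is therefore no basis for expecting a step beyond the scatter in this assay. The estimated step of no change at the digits printed from compound 3 to compound 4 (within the scatter) is accordingly small, and compound 4 is expected to give about 70000 nM, in a range from 30000 nM to 150000 nM.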

Compound 4, half-maximal inhibitory concentration: 100000 nM
Compound 4: middle estimate off by 1.4-fold (0.15 log units), on the low side; the measured number falls inside the stated range.
By their numbers in this assay, from the lowest: compounds 3, 1, 2 and 4 (each within the scatter of the next).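

In this assay, exchanging phenyl for 4-chlorophenyl gives a 1.4-fold higher number from compound 3 to compound 4 (0.15 log units; within the scatter) and so, on these data, a chloro on this aromatic carbon, para to a large group, does not separate the two compounds. Among these compounds, the earlier measured step, trifluoromethyl in place of fluoro, lay elsewhere on the shared core, so this is the first reading at this position, and this step too stays within the usual spread of repeat measurements. Nothing available here explains the result or bears on it.

On these data alone, a single chloro is only one probe of this position, so it remains open whether an amine or a carboxylic acid at the same aromatic carbon would give a step beyond the scatter. The compounds shown also leave open whether chloro would behave in the same way in compound 1 or compound 2, which carry other groups elsewhere on the core.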